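Trifluoromethoxy for fluoro across two cores in Vero cytotoxicity

The compounds below may be only part of what the source reports. "The series", "measured", "known", "first", "only" and "open" are said of these compounds alone.

Measured so far:
compound 1, `O=[N+]([O-])c1cn2c(n1)OC[C@@H](OCc1cccc(-c3ccc(F)cc3)c1)C2`, gives > 128000 nM, a limit of the assay.
compound 2, `O=[N+]([O-])c1cn2c(n1)OC[C@@H](OCc1cccc(-c3ccc(OC(F)(F)F)cc3)c1)C2`, gives > 128000 nM, a limit of the assay.
compound 3, `O=[N+]([O-])c1cn2c(n1)OC[C@@H](OCc1ccc(-c3ccc(F)cc3)s1)C2`, gives > 128000 nM, a limit of the assay.

All three values come from an ADME assay on Vero cells (Chlorocebus sabaeus) for cytotoxicity, with a stated time of 72 h; on this read-out lower numbers stand for stronger inhibition and higher numbers for weaker inhibition. Compound 1 and compound 2 share one core and differ by trifluoromethoxy in place of fluoro on an aromatic carbon. The step that the two limits leave unreadable from compound 1 to compound 2 cannot be sized, because of the limit of > 128000 nM in this assay, at which 3 of the 3 values shown sit. Compound 3 carries a different core; the difference between the two cores is not broken down here. Compound 4, `O=[N+]([O-])c1cn2c(n1)OC[C@@H](OCc1ccc(-c3ccc(OC(F)(F)F)cc3)s1)C2`, is not yet measured and differs from compound 3 by trifluoromethoxy in place of fluoro on an aromatic carbon, the same change as that from compound 1 to compound 2, at a place described in the same words.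

For compound 4 the expected step is a step that the limit leaves unreadable from compound 3 to compound 4, resting on compound 3 at > 128000 nM and on the unsized step from compound 1 to compound 2. Compound 4 is estimated at 200000 nM, between 100000 nM and 500000 nM, most likely reported again as a limit.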

Compound 4, half-maximal inhibitory concentration: > 128000 nM
Compound 4 gave a limit, no number; the forecaster's own chance of this, stated with the estimate: 90%; the middle value does not contradict the limit.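

In this assay, no step can be read from compound 3 to compound 4, and none from compound 1 to compound 2, because every value is a limit and not a number: the limit of > 128000 nM in this assay, at which 4 of the 4 values shown sit.

The compounds shown leave open whether trifluoromethoxy in place of fluoro changes the read-out in this assay on either core.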